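A Methyl Added to the Amine Chain

The compounds below may be only part of what the source reports. "The series", "measured", "known", "first", "only" and "open" are said of these compounds alone.

Compound 1 `COc1ccccc1-c1cc(C2CCN(C)C2)ccc1Cl` and compound 2 `CCNCc1ccc(Cl)c(-c2ccccc2OC)c1` share a core and were both tested in a functional assay on HEK293 cells for agonist activity at 5-hydroxytryptamine receptor 7 (Homo sapiens), read by a luciferase reporter and beta-arrestin recruitment, with a stated time of 22 h; a higher number here means a larger maximal response, a lower number a smaller maximal response. In this assay compound 1 gives 51%. In this assay compound 2 is reported as "not active" (no number reported), so no single number stands for it; on the numbers shown, compound 2 stands without a measured maximal response, while compound 1 reaches a measured one. Compound 3 `CCCNCc1ccc(Cl)c(-c2ccccc2OC)c1` has not yet been measured in this assay. Compound 3 differs from compound 2 by methyl in place of hydrogen on a saturated chain carbon, two bonds along the chain from an amine nitrogen, so that ethylamino becomes propylamino. Going by the values given here, no step between measured compounds has been reported, so the size of the step in this assay can only be expected, not read off: a change of this kind is expected to give a step within the usual scatter, in either direction, and most likely none beyond it, given that compound 2 is "not active" (no number reported). Compound 3 is therefore expected to reach only a small maximal response in this assay, estimated at 12% with a range from 0% to 35%.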

Compound 3, largest response reached (Emax), in percent of the reference or control that the assay uses: "not active" (no number reported)
For compound 3 the study gives words and no number; the estimate stays without a comparison.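

In this assay compound 2 is reported as "not active" (no number reported) and compound 3 as "not active" (no number reported), so no step can be read between them. The compounds shown leave open whether ethylamino to propylamino changes the maximal response at all. No evidence shown bears on this result.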